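Swapping the Thiazole for Cyclopropyl on a Benzimidazole-Type Core

The compounds below may be only part of what the source reports. "The series", "measured", "known", "first", "only" and "open" are said of these compounds alone.

Compound 1 `CCCCOC(=O)NS(=O)(=O)c1ccc(CCC)cc1-c1ccc(Cn2c(-c3nccs3)nc3ccccc32)cc1`: 5.1 nM
Compound 2 `CCCCOC(=O)NS(=O)(=O)c1ccc(CCC)cc1-c1ccc(Cn2cnc3ccccc32)cc1`: 29 nM
Compound 3 `CCCCOC(=O)NS(=O)(=O)c1ccc(CCC)cc1-c1ccc(Cn2c(Cc3ccccc3)nc3ccccc32)cc1`: 15 nM

All three compounds were measured in an assay on membranes from HEK293 cells for displacement of a labelled ligand from Type-2 angiotensin II receptor (Homo sapiens), read by radioligand binding; a higher number here means a weaker inhibitor, a lower number a stronger inhibitor. Compound 1 gives the lowest of the three numbers, so it is the strongest inhibitor in this set; its nearest neighbour is compound 3, and compound 2 is furthest away.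

The compound still to be measured is compound 4 `CCCCOC(=O)NS(=O)(=O)c1ccc(CCC)cc1-c1ccc(Cn2c(C3CC3)nc3ccccc32)cc1`. It differs from compound 1 in one place: cyclopropyl in place of 1,3-thiazol-2-yl on an aromatic carbon.

Among the compounds with values here, two measured steps bear on this change, since both also replace the 1,3-thiazol-2-yl group in compound 1 on the same aromatic carbon. Removing it entirely gave a 5.7-fold higher number from compound 1 to compound 2 (0.75 log units; beyond the scatter), and swapping it for benzyl gave a 2.9-fold higher number from compound 1 to compound 3 (0.47 log units; beyond the scatter). In both cases the number rose, and the rise was modest. A cyclopropyl group is neither the bare hydrogen of compound 2 nor the larger benzyl of compound 3, so a modest rise of similar size is expected here too: the estimated step is a 2.9-fold higher number from compound 1 to compound 4 (0.47 log units; beyond the scatter).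

For compound 4 the expected value in this assay is therefore 15 nM, with a likely range from 6 nM to 40 nM.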

Compound 4, inhibition constant: 31 nM
Estimate against measurement, compound 4: 2.1-fold (0.32 log units) below, and the stated range covers the measured number.
By their numbers in this assay, from the lowest: compound 1; then compounds 3, 2 and 4 (each within the scatter of the next, the first and the last beyond it).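

In this assay, the cyclopropyl ring on this aromatic carbon, between two ring nitrogen atoms, cannot be told apart from bare hydrogen (a 1.1-fold higher number from compound 2 to compound 4 (0.03 log units; within the scatter)), so having a ring at this position is not enough to lower the number. Cyclopropyl does separate from two of the other groups, both the 1,3-thiazol-2-yl group (a 6.1-fold higher number from compound 1 to compound 4 (0.78 log units; beyond the scatter)) and benzyl (a 2.1-fold higher number from compound 3 to compound 4 (0.32 log units; beyond the scatter)), although benzyl itself stays within the scatter of hydrogen (a 1.9-fold lower number from compound 2 to compound 3 (0.29 log units; within the scatter)), which leaves 1,3-thiazol-2-yl as the only group here with a step from hydrogen that lies beyond the scatter. Nothing available explains these differences.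

The compounds shown leave open which feature of the 1,3-thiazol-2-yl group goes with the lower number of compound 1: its aromatic ring, its nitrogen or its sulfur, a question that a phenyl ring on the same carbon, aromatic but of carbon only, would help to separate. They also leave open how an amine or a short open chain such as ethyl would read at this position.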